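Working notes: from 3-fluorobenzyl to 4-methylbenzyl

The compounds below may be only part of what the source reports. "The series", "measured", "known", "first", "only" and "open" are said of these compounds alone.

Values so far in an ADME assay on HEK-293T cells (Homo sapiens) for inhibition, read by CCK-8 assay, with a stated time of 48 h, tested at 20 uM (a lower number here means less inhibition of growth, a higher number more inhibition of growth at the concentration tested), are as follows
- compound 1 `COc1ccc(S(=O)(=O)Oc2ccccc2/C=C(\C#N)C(=O)Nc2nnc(Cc3ccc(F)cc3)s2)cc1` gives 20% here
- compound 2 `COc1ccc(S(=O)(=O)Oc2ccccc2/C=C(\C#N)C(=O)Nc2nnc(Cc3cccc(F)c3)s2)cc1` gives 29% here

Going by the values given here, compound 2 stands within the scatter of compound 1, the only other measured compound, so the two cannot be ranked. Compound 3 `COc1ccc(S(=O)(=O)Oc2ccccc2/C=C(\C#N)C(=O)Nc2nnc(Cc3ccc(C)cc3)s2)cc1` has not been measured yet. Its difference from compound 2 is 4-methylphenyl in place of 3-fluorophenyl on a saturated chain carbon bound to an aromatic carbon. The shared core stays unchanged. Among the compounds with values here, no compound carrying 4-methylphenyl has been measured, so the data give no direct reading on this group. Within the data shown here, only one measured step bears on this place, with 3-fluorophenyl in place of 4-fluorophenyl. Since that single step is a number 9 percentage points higher from compound 1 to compound 2 (within the scatter) no step beyond the scatter is expected in this assay and no direction can be argued from the data. The expected change is a number 3 percentage points lower from compound 2 to compound 3 (within the scatter) on this estimate. Among the measured compounds shown here, with one step as the only guide the range is kept wide. Compound 3 is estimated at 26% (expected range 12% to 42%).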

Compound 3, percent growth inhibition at one concentration: 28%
The estimate for compound 3 lay 2 percentage points below the measured number; measured number inside the range.
By their numbers in this assay, from the lowest: compounds 1, 3 and 2 (each within the scatter of the next).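

In this assay, going by these compounds alone, the first group at this place without fluorine, 4-methylphenyl in place of 3-fluorophenyl, gives a step that cannot be told from no change (a number 1 percentage points lower from compound 2 to compound 3 (within the scatter)). The comparison with the 4-fluorophenyl compound adds a direct reading of methyl in place of fluoro on an aromatic carbon, and this too stays inside the usual variation (a number 8 percentage points higher from compound 1 to compound 3 (within the scatter)). All three steps among compounds 1, 2 and 3 now lie within the scatter, so these three aryl groups on the saturated chain carbon cannot be ranked in this assay, and no information is available to explain this result.

The compounds shown leave open whether 3-methylphenyl would also fall within the scatter of compound 3, which would separate the methyl group's identity from its place on the ring. They also leave open whether an aromatic ring carrying an amine or a carboxylic acid, or a longer chain in place of the saturated chain carbon, would produce a step beyond the scatter from compound 3.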